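The source may report more compounds than this note shows. Statements on the series, on what has been measured and on what is new or still open speak of the compounds shown alone.

In a functional assay on CWR22R cells (Homo sapiens) for antiproliferative activity, read by CCK-8 assay, with a stated time of 6 days (a lower number here means a stronger inhibitor, a higher number a weaker inhibitor), compound 1 (`COC(=O)/C=C/C(=O)N[C@@H](C)Cn1ccc(-c2ccc(C#N)c(Cl)c2)n1`) has the entry "not determined" (no result reported) and offers no number to compare. Compound 2 (`C[C@@H](Cn1ccc(-c2ccc(C#N)c(Cl)c2)n1)Nc1cccnc1`) gives 21600 nM and compound 3 (`Cc1ccnc(N[C@@H](C)Cn2ccc(-c3ccc(C#N)c(Cl)c3)n2)n1`) gives 4760 nM as the lower of the two numbers available. The change to compound 4 (`C[C@@H](Cn1ccc(-c2ccc(C#N)c(Cl)c2)n1)Nc1ncnc2nc[nH]c12`) is a group of 9 heavy atoms (5 carbon, 4 nitrogen; one five-membered aromatic ring with 2 hetero atoms, one six-membered aromatic ring with 2 hetero atoms) in place of a group of 7 heavy atoms (5 carbon, 2 nitrogen; one six-membered aromatic ring with 2 hetero atoms), on an amine nitrogen and leaves the rest of the structure untouched. Within the data shown here, only one measured step bears on it, a 4.5-fold lower number from compound 2 to compound 3 (0.66 log units; beyond the scatter) on swapping the group on that amine nitrogen, modest but beyond the scatter. That single step gives no direction for the group entering here, so no shift beyond the scatter is expected in this assay and the estimated step is a 1.2-fold lower number from compound 3 to compound 4 (0.08 log units; within the scatter) at most slight. The estimate for compound 4 is 4000 nM (expected range 1200 nM to 14000 nM).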

Compound 4, half-maximal inhibitory concentration: 4240 nM
Compound 4: the middle estimate sits 1.1-fold (0.03 log units) below what was measured, within the range that was stated.
By their numbers in this assay, from the lowest: compounds 4 and 3 (each within the scatter of the next); then compound 2.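

In this assay the two-ring group on the amine nitrogen, with its hydrogen-bond donor, gives a 1.1-fold lower number from compound 3 to compound 4 (0.05 log units; within the scatter) against 4-methylpyrimidin-2-yl, so the added five-membered ring brings no difference beyond the scatter. Against pyridin-3-yl it gives a 5.1-fold lower number from compound 2 to compound 4 (0.71 log units; beyond the scatter) and thus stands apart from that group as 4-methylpyrimidin-2-yl does. Nothing available explains these results. The compounds shown leave open whether a group without an aromatic ring on that amine nitrogen, such as a short alkyl chain or a morpholine, would keep this level.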